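Adding a Second Trifluoromethyl to a Diaryl Urea

The compounds below may be only part of what the source reports. "The series", "measured", "known", "first", "only" and "open" are said of these compounds alone.

Compound 1 `COc1cc(Cl)cc(-c2nn(-c3cccc(NC(=O)Nc4cccc(C(F)(F)F)c4)c3)cc2-c2ccncc2)c1` was tested in a functional assay on SF-295 cells (Homo sapiens) for inhibition, read by sulforhodamine B assay, with a stated time of 48 h, tested at 10 uM (on this read-out lower numbers stand for a stronger effect and higher numbers for a weaker effect at the one concentration tested), where compound 1 gives -7.87%. Of the two numbers reported in this assay, compound 1 is the lowest; its nearest neighbour is compound 2 `COc1cc(Cl)cc(-c2nn(-c3cccc(NC(=O)Nc4ccc(Cl)c(Cl)c4)c3)cc2-c2ccncc2)c1`, for which compound 2 gives -2.42%. The step of a number 5.5 percentage points higher from compound 1 to compound 2 (within the scatter) lies within the scatter of the measurement. Compound 3 `COc1cc(Cl)cc(-c2nn(-c3cccc(NC(=O)Nc4cc(C(F)(F)F)cc(C(F)(F)F)c4)c3)cc2-c2ccncc2)c1` has not yet been measured. It differs from compound 1 in one place: trifluoromethyl in place of hydrogen on an aromatic carbon. Among the compounds with values here, the only measured step that bears on this change, the one from compound 1 to compound 2, exchanged one aryl group on the urea nitrogen for another and produced no movement beyond the scatter. On that basis no step beyond the scatter is expected for compound 3, that is, a number 2.9 percentage points higher from compound 1 to compound 3 (within the scatter). Compound 3 is therefore estimated to give -5% in this assay, with a likely range from -20% to 12%.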

Compound 3, a percentage reported as activity, at one concentration (the size of the read-out at that concentration, not a potency): -43.2%
Estimate against measurement, compound 3: 38.2 percentage points above, and the stated range ends above it.
By their numbers in this assay, from the lowest: compound 3; then compounds 1 and 2 (each within the scatter of the next).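

In this assay, trifluoromethyl in place of hydrogen on an aromatic carbon, meta to a trifluoromethyl group, gives a number 35.3 percentage points lower from compound 1 to compound 3 (beyond the scatter). The earlier exchange of one aryl group for another on the urea nitrogen gave only a number 5.5 percentage points higher from compound 1 to compound 2 (within the scatter), so that step alone did not show that the read-out could respond to a change on this aryl group. The compounds shown offer no measurement that would explain the size of the new step.

As far as these compounds go, whether the response belongs to trifluoromethyl in particular or would also appear with another group on this carbon, such as a methoxy group or an amine, remains open. The read-out also comes from a single concentration, so the compounds shown leave open how compound 3 compares with compound 1 in potency.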